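A few compounds are considered here, and "the series" means these few. Any claim that something is new, unique, unknown or untested is made for them only; others in the source may bear on it.

Compound 1 `CCCCCC(=O)OCCc1ccc(O)cc1`, compound 2 `CCCCCCCC(=O)OCCc1ccc(O)cc1` and compound 3 `CCCCCCCCCCCC(=O)OCCc1ccc(O)c(O)c1` have been run in a toxicity assay on MRC5 cells (Homo sapiens) for inhibition, read by MTT assay, with a stated time of 72 h; on this read-out higher numbers stand for weaker inhibition and lower numbers for stronger inhibition. In this assay compound 1 gives 166000 nM and compound 2 gives 133000 nM. The change from compound 2 to compound 1 is hydrogen in place of ethyl on a saturated chain carbon, five bonds along the chain from a carbonyl carbon, and it makes a 1.2-fold higher number from compound 2 to compound 1 (0.10 log units; within the scatter). Compound 3 stands at 38100 nM in this assay, the lowest of the three numbers; how the core of compound 3 differs from the core of compound 2 is not broken down here.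

Compound 4 `CCCCCCCCCC(=O)OCCc1ccc(O)c(O)c1` is not yet measured. It differs from compound 3 by hydrogen in place of ethyl on a saturated chain carbon, nine bonds along the chain from a carbonyl carbon. Going by the values given here, this is the same kind of change as the one from compound 2 to compound 1, not the same: there the place is five bonds along the chain from a carbonyl carbon, here it is nine bonds along the chain from a carbonyl carbon. Because a 1.2-fold higher number from compound 2 to compound 1 (0.10 log units; within the scatter) stayed within the scatter, only a small step is expected here too, a 1.2-fold higher number from compound 3 to compound 4 (0.08 log units; within the scatter), with the number for compound 4 expected to sit slightly above that of compound 3. Compound 4 is thus estimated at 46000 nM in this assay, with an expected range from 24000 nM to 95000 nM.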

Compound 4, half-maximal inhibitory concentration: 71100 nM
The estimate for compound 4 lay 1.5-fold (0.19 log units) below the measured number; the range from low to high includes it.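

Hydrogen in place of ethyl, nine bonds along the chain from a carbonyl carbon, gives a 1.9-fold higher number from compound 3 to compound 4 (0.27 log units; within the scatter) in this assay. Set beside the same kind of change five bonds along the chain on the other core, this step carries over with no difference that can be told from the scatter: the same change on two cores in this assay, a 1.2-fold higher number (0.10 log units; within the scatter) from compound 2 to compound 1 and a 1.9-fold higher number (0.27 log units; within the scatter) from compound 3 to compound 4, 1.5-fold (0.17 log units) apart, within the scatter of two such steps
This supports only a small step for this change on both cores in this assay; it does not show that the two steps are equal or that the change would stay small elsewhere on the chain, and the place along the chain differs together with the core, so the data do not separate the two.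

Still open is how the two cores compare at a matched chain, since no pair shown differs in the core alone. Also open, as far as these compounds go, is how a longer chain, or an amide or a carboxylic acid in place of the ester, would read in this assay.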